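Adding a Methoxy Group: Does Cytotoxicity Shift?

This account rests on a few compounds, and the source may have more. Where it says the series, first, only, none or still open, it means among the compounds named here.

Measured so far:
Compound 1, `COc1cc(-c2cc(/C=C/C(=O)c3ccc(N)cc3)[nH]n2)cc(OC)c1OC`, gives -3% in a functional assay on K562 cells (Homo sapiens) for cytotoxicity, read by sulforhodamine B assay, with a stated time of 48 h, tested at 100 uM; a higher number here means a weaker effect of the compound at the concentration tested, a lower number a stronger effect.
Compound 2, `COc1ccc(C(=O)/C=C/c2cc(-c3cc(OC)c(OC)c(OC)c3)n[nH]2)cc1OC`, gives -15% in this assay.
Compound 3, `COc1ccc(-c2cc(/C=C/C(=O)c3ccc(N)cc3)[nH]n2)cc1OC`, gives -3% in this assay.

Going from compound 3 to compound 1, one group is added: methoxy in place of hydrogen on an aromatic carbon. This left the read-out where it was: no change at the digits printed from compound 3 to compound 1 (within the scatter). A different kind of exchange gave a clearer shift, a number 12 percentage points lower from compound 1 to compound 2 (beyond the scatter), and compound 2 ends lowest of the three. How the cores of compound 2 and compound 3 differ is not broken down here.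

Compound 4, `COc1cc(C(=O)/C=C/c2cc(-c3cc(OC)c(OC)c(OC)c3)n[nH]2)cc(OC)c1OC`, awaits measurement. Relative to compound 2 it carries the same change that compound 1 carries relative to compound 3: methoxy in place of hydrogen on an aromatic carbon. Because no change at the digits printed from compound 3 to compound 1 (within the scatter) stayed within the scatter, a similarly small step is expected in this assay: a number 1 percentage points higher from compound 2 to compound 4 (within the scatter). Compound 4 is therefore estimated at -14%, most likely between -32% and 4%.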

Compound 4, a percentage reported as activity, at one concentration (the size of the read-out at that concentration, not a potency): 1%
Compound 4: the middle estimate sits 15 percentage points below what was measured, and the stated range covers the measured number.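

On the core of compound 2, putting a methoxy group in place of a hydrogen on an aromatic carbon gave a number 16 percentage points higher from compound 2 to compound 4 (beyond the scatter) in this assay. The same change did not bring the same step on the two cores: the same change on two cores in this assay, no change at the digits printed (within the scatter) from compound 3 to compound 1 and a number 16 percentage points higher (beyond the scatter) from compound 2 to compound 4, 16 percentage points apart, beyond the scatter of two such steps

So the result of this change on one core was a poor guide to its result on the other, but two pairs give no general rule for the series and do not show why the steps differ. The compounds shown leave open whether this gap belongs to methoxy alone or would also appear with a hydroxyl group or a longer ethoxy chain in the same place. Going by these compounds, how the change behaves on any further core also remains open.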